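A Second Chlorine on the Shared Core

The compounds below may be only part of what the source reports. "The series", "measured", "known", "first", "only" and "open" are said of these compounds alone.

Measured compounds:
compound 1 `N#Cc1c(Nc2ccccc2)nc(SCC(=O)Nn2c(COc3ccc(Cl)cc3Cl)nc3ccccc3c2=O)nc1-c1ccccc1` — 78.1%
compound 2 `N#Cc1c(Nc2ccc(Cl)cc2)nc(SCC(=O)Nn2c(COc3ccc(Cl)cc3Cl)nc3ccccc3c2=O)nc1-c1ccccc1` — 57.9%

In a functional assay on the whole organism (strain albino) for inhibition, with Rattus norvegicus as the target, read by paw edema, with stated times of 1 h and 2 h, at a dose of 100 mg/kg by the oral route (a lower number here means less inhibition, a higher number more inhibition at the dose given (going by the name of the read-out)), compound 1 gives 78.1%, while compound 2 gives 57.9%. Among the measured compounds shown here, compound 2 stands lowest of the two numbers; its only neighbour is compound 1, and the step of a number 20.2 percentage points lower from compound 1 to compound 2 (beyond the scatter) lies beyond the scatter. Compound 3 `N#Cc1c(Nc2ccc(Cl)cc2)nc(SCC(=O)Nn2c(COc3ccc(Cl)cc3Cl)nc3ccccc3c2=O)nc1-c1ccc(Cl)cc1` has not yet been measured in this assay. It differs from compound 2 by chloro in place of hydrogen on an aromatic carbon; the same difference, cut one bond further out, reads phenyl to 4-chlorophenyl. For the measured compounds named here, only one measured step bears on such a change, the step of a number 20.2 percentage points lower from compound 1 to compound 2 (beyond the scatter), in which chloro in place of hydrogen on an aromatic carbon of a different ring lowered the number modestly. That step sits on another part of the shared core, so it is a guide of limited weight. Because a number 20.2 percentage points lower from compound 1 to compound 2 (beyond the scatter) went down, a downward step of similar or smaller size, or none beyond the scatter, is expected for compound 3. For compound 3 in this assay the expected value is 50%, with a range from 32% to 66%. The step this estimate means is a number 7.9 percentage points lower from compound 2 to compound 3 (within the scatter).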

Compound 3, a percentage reported as inhibition, in the whole organism at one dose (the size of the read-out at that dose, not a potency): 61.4%
The estimate for compound 3 lay 11.4 percentage points below the measured number, within the range that was stated.
By their numbers in this assay, from the lowest: compounds 2 and 3 (each within the scatter of the next); then compound 1.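

In this assay, the change from phenyl to 4-chlorophenyl gives a number 3.5 percentage points higher from compound 2 to compound 3 (within the scatter), so a chloro at this position, on a six-membered aromatic ring of carbon only, leaves the read-out within the scatter of compound 2. The earlier exchange of hydrogen for chloro, on an aromatic carbon of a different ring, gave a number 20.2 percentage points lower from compound 1 to compound 2 (beyond the scatter), so the two steps show that the same exchange need not carry the same outcome from one ring of the shared core to another. No measurement is available that would explain this difference between the two rings.

The compounds shown leave open whether the result at this position depends on the chloro already present on the other ring, a question that only the 4-chlorophenyl group paired with the unsubstituted ring of compound 1 could answer. They also leave open how this position would respond to a group other than chloro, such as a methoxy group, an amine or a carboxylic acid, since hydrogen and chloro are the only two substituents seen there.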